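Replacing hydroxymethyl with methylcarbamoyl on a shared core

The source may report more compounds than this note shows. Statements on the series, on what has been measured and on what is new or still open speak of the compounds shown alone.

In a physicochemical assay for lipophilicity, at pH 7.4 (a higher number here means a more lipophilic compound, a lower number a more polar compound), compound 1 `Cc1cc(/C=C/C#N)cc(C)c1Oc1cc(Nc2ccc(C#N)cc2)c(N)cc1C(F)(F)F` gives > 5, which is a limit of the assay and not a number.

Among the compounds with values here, compound 2 `Cc1cc(/C=C/C#N)cc(C)c1Oc1cc(Nc2ccc(C#N)cc2)c(N)cc1CO` gives 4.14, so it holds the only true number so far.

The next compound, compound 3 `CNC(=O)c1cc(N)c(Nc2ccc(C#N)cc2)cc1Oc1c(C)cc(/C=C/C#N)cc1C`, keeps the core of compound 2 and changes one group: methylcarbamoyl in place of hydroxymethyl on an aromatic carbon. Methylcarbamoyl takes the place of hydroxymethyl on an aromatic carbon, ortho to a large group.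

Within the data shown here, only one measured step bears on this change. It is a number at least 0.86 log units lower from compound 1 to compound 2 (beyond the scatter), and it brought hydroxymethyl in place of trifluoromethyl on an aromatic carbon. That step shows that a swap of a single group can move the reading in this assay by a clear amount. However, it involved trifluoromethyl, and methylcarbamoyl has not been measured on this core, so it serves only as a loose guide here.

With so little to go on, no shift beyond the scatter is expected, and the estimated step is a number 0.14 log units lower from compound 2 to compound 3 (within the scatter). For compound 3 the expected value is 4, within an estimated range from 3.5 to 4.5.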

Compound 3, partition coefficient: 4.12
Beside the measured number, compound 3's estimate is 0.12 log units below it; the range from low to high includes it.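

In this assay, swapping hydroxymethyl for methylcarbamoyl gives a number 0.02 log units lower from compound 2 to compound 3 (within the scatter), so at this position on the shared core the two groups cannot be told apart by this reading, even though methylcarbamoyl has 4 heavy atoms where hydroxymethyl has 2, and each has 1 hydrogen-bond donor and 1 hydrogen-bond acceptor. Putting methylcarbamoyl in place of trifluoromethyl gives a number at least 0.88 log units lower from compound 1 to compound 3 (beyond the scatter), so two different groups, hydroxymethyl and methylcarbamoyl, now both read clearly lower than trifluoromethyl at this position, which a single step could not show. The full size of these two steps from compound 1 stays unknown because compound 1 has only a limit of the assay and not a true number: the limit of > 5 in this assay, at which 1 of the 3 values shown sits.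

The compounds shown leave open whether other groups at this position, such as a carboxylic acid, an aminomethyl group or a longer chain ending in an alcohol, would also read like hydroxymethyl and methylcarbamoyl or would stand apart from them. They also leave open whether swapping hydroxymethyl for methylcarbamoyl would read the same way on a different core.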